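Replacing 3-chlorophenyl with cyclohexyl on compound 1

The source may hold more compounds than are shown below. What is called first, only, known or untested is meant among the compounds shown, and "the series" means these compounds.

Compound 1 `O=C(NCc1cc(Cl)ccc1-n1cnnn1)[C@@H]1C[C@@H]2C[C@@H]2N1C(=O)[C@H](O)c1cccc(Cl)c1` gives > 500 mL.min-1.g-1 (a limit)
Compound 2 `O=C(NCc1cc(Cl)ccc1-n1cnnn1)[C@@H]1CC=NN1C(=O)[C@H](O)c1ccccc1F` gives 16 mL.min-1.g-1
Compound 3 `CC(C)(C)[C@@H](O)C(=O)N1C[C@@H]2C[C@@H]2[C@H]1C(=O)NCc1cc(Cl)ccc1-n1cnnn1` gives < 15 mL.min-1.g-1 (a limit)

In an ADME assay on liver for metabolic stability, with Liver microsome (Homo sapiens) as the target, read by LC-MS, using microsomes (on this read-out lower numbers stand for slow clearance and higher numbers for fast clearance), compound 1 gives > 500 mL.min-1.g-1 as a limit of the assay and not as a number. Compound 4 `O=C(NCc1cc(Cl)ccc1-n1cnnn1)[C@@H]1C[C@@H]2C[C@@H]2N1C(=O)[C@H](O)C1CCCCC1` keeps the core of compound 1 and carries cyclohexyl in place of 3-chlorophenyl on a saturated chain carbon bound to a carbonyl carbon and an oxygen on a saturated carbon. Among the compounds with values here, no measured pair isolates this change. Compound 3 has no aromatic ring on that carbon and gives < 15 mL.min-1.g-1 as a limit. Compound 2 keeps an aromatic ring there yet gives 16 mL.min-1.g-1 in this assay so these two offer only weak guidance. The expected step is an at least 2.5-fold lower number from compound 1 to compound 4 (0.39 log units; beyond the scatter) as a fall in clearance, with a reading at the limit still possible. For compound 4 the estimated value is 200 mL.min-1.g-1 (expected range 50 mL.min-1.g-1 to 500 mL.min-1.g-1).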

Compound 4, intrinsic clearance in microsomes: 150 mL.min-1.g-1
Compound 4: middle estimate off by 1.3-fold (0.12 log units), on the high side; measured number inside the range.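

Cyclohexyl in place of 3-chlorophenyl gives an at least 3.3-fold lower number from compound 1 to compound 4 (0.52 log units; beyond the scatter) in this assay, the first step at this position with the core of compound 1 held constant. It shows that the group on this carbon alone can bring a reading off the limit, and compound 4 gives a number. On these data alone, compound 1 stands at a limit of the assay, so the full size of the step remains unknown: the limit of > 500 mL.min-1.g-1 in this assay, at which 1 of the 4 values shown sits.

As far as these compounds go, the aromatic ring and the chlorine leave together, so their separate shares stay open. Plain phenyl or a cyclohexyl carrying an amine at this position would help to separate them.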